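This account rests on a few compounds, and the source may have more. Where it says the series, first, only, none or still open, it means among the compounds named here.

Of the compounds shown here, two on the shared core have been measured in a functional assay on A549 cells (Homo sapiens) for cytotoxicity, read by MTT assay, with a stated time of 72 h; on this read-out lower numbers stand for stronger inhibition and higher numbers for weaker inhibition. Compound 1 `COc1ccc2c(c1)[n+]([O-])nc(NCOC(C)c1ccccc1)[n+]2[O-]` gives 220 nM. Compound 2 `[O-][n+]1nc(NCOC2CCCCC2)[n+]([O-])c2ccccc21` gives 1200 nM, the higher of the two numbers, and its gap to compound 1 lies beyond the scatter. Compound 3 `CCCCCCCOCNc1n[n+]([O-])c2ccccc2[n+]1[O-]` is not yet measured. It differs from compound 2 in one place: heptyl in place of cyclohexyl on an oxygen on a saturated carbon. Among the measured compounds shown here, no measured pair shows this change. The step from compound 2 to compound 3 is therefore expected to stay within the scatter, with no set direction, no change at the digits printed from compound 2 to compound 3 (within the scatter). Compound 3 is estimated at 1200 nM, in the range 400 nM to 3600 nM.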

Compound 3, half-maximal inhibitory concentration: 3490 nM
For compound 3 the middle estimate is 2.9-fold (0.46 log units) below the measured one; measured number inside the range.
By their numbers in this assay, from the lowest: compound 1; then compound 2; then compound 3.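

In this assay, the group on the oxygen on a saturated carbon is not interchangeable: heptyl in place of cyclohexyl gives a step beyond the scatter, though a modest one (a 2.9-fold higher number from compound 2 to compound 3 (0.46 log units; beyond the scatter)). Activity on this read-out therefore responds to a change at this position. No measurement in hand accounts for the step.

Heptyl and cyclohexyl differ both in the ring and in carbon count, so the pair does not separate the two. A hexyl chain on this oxygen, on the core of compound 2, remains the open comparison.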